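Notes on compound 4 among three measured analogues

This account rests on a few compounds, and the source may have more. Where it says the series, first, only, none or still open, it means among the compounds named here.

Measured so far:
compound 1 `CC(C)c1onc(-c2c(Cl)cccc2Cl)c1COc1ccc(-c2nc3ccc(C(=O)O)cc3n2CC2CCCCC2)c(F)c1`: 840 nM
compound 2 `CC(C)c1onc(-c2c(Cl)cccc2Cl)c1COc1ccc(-c2nc3ccc(C(=O)O)cc3n2-c2ccc(F)cc2)cc1`: 2410 nM
compound 3 `CC(C)c1onc(-c2c(Cl)cccc2Cl)c1COc1ccc(-c2nc3ccc(C(=O)O)cc3n2C)c(Cl)c1`: 3520 nM

All three were measured in an assay on HEK-293T cells for antagonist activity at vitamin D3 receptor (Homo sapiens), read by a luciferase reporter, with a stated time of 24 h; a lower number here means a stronger inhibitor, a higher number a weaker inhibitor. Compound 2 holds the second highest number of the three. Compound 3 lies within the usual scatter of compound 2, so no order between them can be stated; compound 1 gives a clearly lower number, beyond the scatter. Compound 4 `CC(C)c1onc(-c2c(Cl)cccc2Cl)c1COc1ccc(-c2nc3ccc(C(=O)O)cc3n2C2CCC2)cc1` differs from compound 2 in one place: cyclobutyl in place of 4-fluorophenyl on an aromatic nitrogen. Within the data shown here, no measured pair isolates this change, and compounds 1 and 3 differ from compound 2 elsewhere as well. The lower number of compound 1 840 nM hints that a non-aromatic group on that nitrogen may be tolerated, though this rests on one compound. The step from compound 2 to compound 4 is expected to be small, toward a lower number, near the edge of the scatter, a 1.5-fold lower number from compound 2 to compound 4 (0.18 log units; within the scatter). Compound 4 is thus estimated at 1600 nM, within 600 nM to 4500 nM.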

Compound 4, half-maximal inhibitory concentration: 1100 nM
Compound 4: the middle estimate sits 1.5-fold (0.16 log units) above what was measured; measured number inside the range.
By their numbers in this assay, from the lowest: compounds 1 and 4 (each within the scatter of the next); then compounds 2 and 3 (each within the scatter of the next).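

In this assay, among these compounds, the pair gives a 2.2-fold lower number from compound 2 to compound 4 (0.34 log units; beyond the scatter) as a modest step beyond the scatter, the first reading that isolates this position. On this aromatic nitrogen, an aromatic ring is therefore not needed to keep activity, and cyclobutyl gives the lower number despite having fewer heavy atoms than 4-fluorophenyl. No measurement at hand accounts for the step. Still open, going by these compounds, is how an open alkyl chain or an amine-bearing chain on this nitrogen would compare with cyclobutyl. Also open, on these data alone, is whether the step carries over to a core bearing a halogen on its phenyl ring.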